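This account rests on a few compounds, and the source may have more. Where it says the series, first, only, none or still open, it means among the compounds named here.

Working notes on the series. The shared core is carried by compound 1 `COc1ccc2[nH]c(C(=O)N3CC(=O)N(Cc4ccccc4)[C@@H](COCc4ccccc4)C3)cc2c1`, compound 2 `Cc1ccc2[nH]c(C(=O)N3CC(=O)N(Cc4ccccc4)[C@@H](CN4CCC5(CCC5)CC4)C3)cc2c1` and compound 3 `COc1ccc2[nH]c(C(=O)N3CC(=O)N(Cc4ccccc4)[C@@H](N4CCC(Cc5ccccc5)CC4)C3)cc2c1`, all tested in an ADME assay on Vero cells (Chlorocebus sabaeus) for cytotoxicity, with a stated time of 7 days; a lower number here means that less compound is tolerated, a higher number that more compound is tolerated. For compound 1 this assay returns only a limit, > 30000 nM, so no number places it on a scale. Compound 3 likewise gives only a limit, > 30000 nM. Compound 2 gives a number, 7800 nM. Within the data shown here, two of the three values thus sit at the limit of > 30000 nM in this assay, at which 2 of the 3 values shown sit, and no pair of compounds differing in a single place has been measured, so no step size is available to lean on.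

Compound 4 `COc1ccc2[nH]c(C(=O)N3CC(=O)N(Cc4ccccc4)[C@@H](CN4C(=O)c5ccccc5C4=O)C3)cc2c1` is the next compound. It differs from compound 1 by a group of 11 heavy atoms (8 carbon, 1 nitrogen, 2 oxygen; one five-membered non-aromatic ring with 1 hetero atom, one six-membered aromatic ring of carbon only) in place of a group of 8 heavy atoms (7 carbon, 1 oxygen; one six-membered aromatic ring of carbon only), on a saturated chain carbon bound to a saturated ring carbon. Among the measured compounds shown here, with no measured step to guide the direction, the expectation for this assay is no shift beyond the scatter, and the step from compound 1 to compound 4 is estimated as a number no higher from compound 1 to compound 4 (the limit leaves the size open). Compound 4 is accordingly expected to fall around 30000 nM, with a range of 10000 nM to 100000 nM, with a fair chance that only a limit is again reported.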

Compound 4, half-maximal cytotoxic concentration: 41000 nM
Estimate against measurement, compound 4: 1.4-fold (0.14 log units) below; the measured number falls inside the stated range.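

Compound 1 returns only a limit in this assay, so no step to compound 4 can be read: the limit of > 30000 nM in this assay, at which 2 of the 4 values shown sit.

The compounds shown leave open how far, or in which direction, replacing benzyloxy on this saturated chain carbon moves the half-maximal cytotoxic concentration.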